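The compounds below may be only part of what the source reports. "The series", "measured", "known", "first", "only" and "open" are said of these compounds alone.

Of the compounds shown here, two of a shared core have been measured in a functional assay on HT-29 cells (Homo sapiens) for inhibition, read by MTT assay, with a stated time of 48 h; on this read-out higher numbers stand for weaker inhibition and lower numbers for stronger inhibition. Compound 1, `Cc1ccc(NC(=S)NC(=O)c2ccc(OCc3cccc(F)c3)cc2)cc1-c1nc2ccccc2[nH]1`, gives 55300 nM. Compound 2, `Cc1ccc(NC(=O)NC(=O)c2ccc(OCc3cccc(Cl)c3)cc2)cc1-c1nc2ccccc2[nH]1`, gives 15400 nM. Of the two numbers, compound 2 has the lower one, and its gap to compound 1 lies beyond the scatter of repeated measurements; compound 1 and compound 2 differ in more than one place, so the pair shows only these two values and no single step can be read from it.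

Compound 3, `Cc1ccc(COc2ccc(C(=O)NC(=O)Nc3ccc(C)c(-c4nc5ccccc5[nH]4)c3)cc2)cc1`, has not yet been measured. It differs from compound 2 in one place: 4-methylphenyl in place of 3-chlorophenyl on a saturated chain carbon bound to an oxygen on an aromatic ring. For the measured compounds named here, no measured pair isolates this change, so there is nothing to fix its size or direction. Because compound 2 gives 15400 nM and the change is small in count, the step from compound 2 to compound 3 in this assay is expected to stay within the usual scatter, estimated as a 1.3-fold higher number from compound 2 to compound 3 (0.11 log units; within the scatter). Compound 3 is therefore estimated to give about 20000 nM in this assay, within a range from 7000 nM to 60000 nM.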

Compound 3, half-maximal inhibitory concentration: 5110 nM
For compound 3 the middle estimate is 3.9-fold (0.59 log units) above the measured one, outside the stated range (below it).
By their numbers in this assay, from the lowest: compound 3; then compound 2; then compound 1.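

In this assay, putting 4-methylphenyl in place of 3-chlorophenyl on a saturated chain carbon bound to an oxygen on an aromatic ring gives a 3.0-fold lower number from compound 2 to compound 3 (0.48 log units; beyond the scatter). This single change at this position moves the read-out by more than the scatter of repeated measurements. This is the first pair shown that isolates one change, and the two groups have the same count of heavy atoms and the same kind of ring, differing in the chlorine and the methyl carbon; steps involving compound 1 still cannot be read, as it differs from the others in more than one place. Nothing measured here accounts for the lower number, so the step stands as an observation without an explanation.

A single pair cannot show whether the step follows from the methyl group, from the loss of the chlorine, or from the different place of the group on the ring. From the compounds shown here alone, how this position would respond to a plain phenyl, a methoxy group, an amine or a carboxylic acid on that ring, or to a longer chain before the ring, also remains open.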